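Adding a Fluoro Group to a Quinoline-Bearing Ester

The compounds below may be only part of what the source reports. "The series", "measured", "known", "first", "only" and "open" are said of these compounds alone.

Measured compounds:
- compound 1 `CC(c1c(F)cc2ncccc2c1F)n1cnc2ncc(-c3cnn(C)c3)nc21`: 63 uL/min
- compound 2 `CC(c1c(F)cc2ncccc2c1F)n1cnc2ncc(-c3ccncc3)nc21`: 77 uL/min
- compound 3 `COC(=O)c1ccc(-c2cnc3ncn(C(C)c4cc5cccnc5cc4F)c3n2)cc1F`: 125 uL/min

These three compounds were tested in an ADME assay on microsomes from liver (Rattus norvegicus) for metabolic stability, read by LC-MS, using NADPH, with stated times of 5 min and 30 min, tested at 1 uM; a lower number here means slower removal, a higher number faster removal of the compound. Compound 3 carries the highest of the three numbers, but neither gap is meaningful: compound 2 sits a 1.2-fold higher number from compound 1 to compound 2 (0.09 log units; within the scatter) away from compound 1, and compound 3 lies within the usual scatter of both compound 2 and compound 1, so the three values cannot be ranked with confidence.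

Compound 4 `COC(=O)c1ccc(-c2cnc3ncn(C(C)c4c(F)cc5ncccc5c4F)c3n2)cc1F` has not yet been measured. It differs from compound 3 by fluoro in place of hydrogen on an aromatic carbon, on an aromatic carbon of a six-membered aromatic ring of carbon only, part of a fused system of two rings, ortho to a fused ring and meta to the fluoro group already present. Going by the values given here, no measured pair shows this particular change, so the only guide is that compound 1 and compound 2, which share the same fluorinated bicyclic part as compound 4, give numbers within the scatter of compound 3. A step of no more than the scatter is therefore expected in this assay, with no clear direction.

Compound 4 is estimated at 105 uL/min, with a range from 55 uL/min to 200 uL/min, which is expected to correspond to a step of a 1.2-fold lower number from compound 3 to compound 4 (0.08 log units; within the scatter).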

Compound 4, intrinsic clearance in a liver preparation (reported as CLH), per the amount of preparation that the assay uses: 179 uL/min
Estimate against measurement, compound 4: 1.7-fold (0.23 log units) below; low and high end bracket the measured number.
By their numbers in this assay, from the lowest: compounds 1, 2, 3 and 4 (each within the scatter of the next, the first and the last beyond it).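

In this assay, fluoro in place of hydrogen on this aromatic carbon, ortho to a fused ring and meta to the fluoro group already present, gives a 1.4-fold higher number from compound 3 to compound 4 (0.16 log units; within the scatter), so this single change cannot be told apart from no change at all. Its value lies in the comparisons it opens among compounds with the same two fluoro groups: 3-fluoro-4-(methoxycarbonyl)phenyl in place of pyridin-4-yl gives a 2.3-fold higher number from compound 2 to compound 4 (0.37 log units; beyond the scatter), and in place of 1-methyl-1H-pyrazol-4-yl it gives a 2.8-fold higher number from compound 1 to compound 4 (0.45 log units; beyond the scatter), both modest but beyond the scatter, unlike the step between the pyridin-4-yl and 1-methyl-1H-pyrazol-4-yl compounds. No separate measurement is available to explain these numbers.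

A single pair cannot show whether this fluoro step would read the same with the pyridin-4-yl or 1-methyl-1H-pyrazol-4-yl group, or what a chloro or methoxy group on the same aromatic carbon would do. As far as these compounds go, it also remains open whether the higher numbers belong to the methyl ester itself, a question that a carboxylic acid or an amide in its place could address.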